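A few compounds are considered here, and "the series" means these few. Any claim that something is new, unique, unknown or untested is made for them only; others in the source may bear on it.

In a functional assay on HOP-62 cells (Homo sapiens) for inhibition, read by sulforhodamine B assay, with a stated time of 48 h (a higher number here means that more compound is tolerated, a lower number that less compound is tolerated), most of this small set reaches only the edge of measurement. Compound 1, `COc1cc(C)cc(-c2c(-c3ccnc(-c4ccc(C(C)=O)cc4)c3)cnn2CC#N)c1`, gives > 100000 nM, which is a limit of the assay rather than a number. Compound 2, `COc1cc(C)cc(-c2nn(CC#N)cc2-c2ccc(-c3cccc(C(C)=O)c3)nc2)c1`, likewise gives > 100000 nM, again a limit. Going by the values given here, compound 3, `Cc1cc(O)cc(-c2nn(CC#N)cc2-c2ccnc(-c3ccc(Oc4ccccc4)cc3)c2)c1`, is the one compound with a stated value, at 52300 nM in this assay, and so is the single number set against (the limit of > 100000 nM in this assay, at which 2 of the 3 values shown sit).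

Compound 4, `Cc1cc(O)cc(-c2nn(CC#N)cc2-c2ccnc(-c3ccc(N(C)C)cc3)c2)c1`, has not yet been measured in this assay. It differs from compound 3 in one place: dimethylamino in place of phenoxy on an aromatic carbon, para to a large group. Among the compounds with values here, no step between measured compounds is available to gauge such a change, so the expectation rests only on compound 3 standing alone with a number while the other two sit at the limit. In this assay the expected step of a 1.3-fold higher number from compound 3 to compound 4 (0.13 log units; within the scatter) is modest, more likely toward a higher figure than a lower one, and may not exceed the usual scatter. Compound 4 is therefore expected to give about 70000 nM in this assay, with a range from 30000 nM to 150000 nM, and a fair chance that only a limit is reported.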

Compound 4, concentration lethal to 50% of the cells: > 100000 nM
Compound 4: a limit, no number; the forecaster's own chance of this, stated with the estimate: 40%; at least 1.4-fold (0.15 log units) between middle value and limit.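

In this assay, going by these compounds alone, this is the first step between two compounds that differ in one place: dimethylamino in place of phenoxy on an aromatic carbon, para to a large group, gives an at least 1.9-fold higher number from compound 3 to compound 4 (0.28 log units; that floor lies within the scatter). Compound 4 gives > 100000 nM, which is a limit of the assay and not a number. Within the data shown here, the step is thus only a floor, its true size stays unknown, and that floor lies within the scatter, so phenoxy remains the only group at this place tied to a stated number while the set sits still more at the edge of measurement: the limit of > 100000 nM in this assay, at which 3 of the 4 values shown sit.

As far as these compounds go, whether a methylamino group, a carboxylic acid or a longer chain such as benzyloxy at this place would give a stated number rather than a limit stays open. The other differences among the compounds cannot be read, as compounds 1 and 2 differ from compound 3 in more than one place, so nothing shown isolates the methoxy group they carry from the hydroxyl group of compound 3.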